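The source may hold more compounds than are shown below. What is called first, only, known or untested is meant among the compounds shown, and "the series" means these compounds.

Measured in a functional assay on NPC-TW01 cells (Homo sapiens) for inhibition; on this read-out lower numbers stand for stronger inhibition of growth and higher numbers for weaker inhibition of growth:
- compound 1 `Clc1ccc(-c2nn(-c3ccccc3)c3ncncc23)cc1`: 23000 nM
- compound 2 `Cc1ccc(-c2nn(-c3ccc4ccccc4n3)c3ncncc23)cc1`: 30000 nM

Compound 2, at 30000 nM, lies within the usual scatter of compound 1, at 23000 nM, so the two cannot be told apart on these numbers. The next compound to be tested in this assay is compound 3 `Clc1ccc(-c2nn(-c3ccc4ccccc4n3)c3ncncc23)cc1`. It differs from compound 2 by chloro in place of methyl on an aromatic carbon, the change from 4-methylphenyl to 4-chlorophenyl: chloro in place of methyl on an aromatic carbon. Within the data shown here, no measured pair shows this exchange on its own, so the only guide is the close agreement of the two values in hand. No step beyond the scatter is expected, and the estimate amounts to a 1.4-fold lower number from compound 2 to compound 3 (0.13 log units; within the scatter). For compound 3 the expected value is 22000 nM, with an estimated range of 10000 nM to 50000 nM.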

Compound 3, concentration for 50% growth inhibition: 35000 nM
Compound 3: middle estimate off by 1.6-fold (0.20 log units), on the low side; measured number inside the range.
By their numbers in this assay, from the lowest: compounds 1, 2 and 3 (each within the scatter of the next).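

In this assay, the exchange of methyl for chloro on an aromatic carbon, para to a large group, gives a 1.2-fold higher number from compound 2 to compound 3 (0.07 log units; within the scatter), so the two compounds cannot be told apart. Among these compounds, this is the first pair that isolates this change, which the earlier compounds could not do, and on this background the 4-methylphenyl and 4-chlorophenyl forms show no difference beyond the scatter. Nothing available here explains this result.

On these data alone, whether an amine, a carboxylic acid or a longer chain at this position would move the number beyond the scatter remains open. As far as these compounds go, it is also open whether methyl and chloro would remain indistinguishable at this position if another part of the molecule were changed.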